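The compounds below may be only part of what the source reports. "The series", "measured", "known", "first", "only" and "open" are said of these compounds alone.

Within the data shown here, compound 2 `COc1ccc(C(=O)/C=C/c2cc(-c3cc(OC)c(OC)c(OC)c3)n[nH]2)cc1OC` holds the lower of the two numbers measured so far: in a functional assay on PC-3 cells (Homo sapiens) for cytotoxicity, read by sulforhodamine B assay, with a stated time of 48 h, tested at 1 uM (on this read-out lower numbers stand for a stronger effect and higher numbers for a weaker effect at the one concentration tested), compound 2 gives 71%, whereas compound 1 `COc1cc(-c2cc(/C=C/C(=O)c3ccc(Cl)c(Cl)c3)[nH]n2)cc(OC)c1OC` gives 87%. Among the measured compounds shown here, the only measured step, a number 16 percentage points lower from compound 1 to compound 2 (beyond the scatter), exchanged the whole ring on the carbonyl carbon. Compound 3 `COc1cc(C(=O)/C=C/c2cc(-c3cc(OC)c(OC)c(OC)c3)n[nH]2)cc(OC)c1OC` differs from compound 2 by a much smaller change: methoxy in place of hydrogen on an aromatic carbon. For the measured compounds named here, no measured step involves adding a methoxy group, so the expectation rests on little; a small step is expected, a number 6 percentage points lower from compound 2 to compound 3 (within the scatter), possibly within the scatter. Compound 3 is estimated at 65%, in a range from 48% to 85%.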

Compound 3, a percentage reported as activity, at one concentration (the size of the read-out at that concentration, not a potency): 74%
Estimate against measurement, compound 3: 9 percentage points below; measured number inside the range.
By their numbers in this assay, from the lowest: compounds 2 and 3 (each within the scatter of the next); then compound 1.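

In this assay, placing a methoxy group on the aromatic carbon ortho to a methoxy group gives a number 3 percentage points higher from compound 2 to compound 3 (within the scatter). At this position, then, the added methoxy group leaves the number within the usual scatter, a much smaller effect than the exchange of the whole ring gave earlier. No available evidence accounts for this result. On these data alone, whether a different group at this position, such as an amine, a carboxylic acid or a longer chain like butoxy, would move the number beyond the scatter remains open.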